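Moving the Two Fluorines on the Cyclopropyl Aryl Ring

The source may hold more compounds than are shown below. What is called first, only, known or untested is meant among the compounds shown, and "the series" means these compounds.

Compound 1 `CC[C@H](C)[C@H](N)CN(C(=O)[C@@H]1C[C@H]1c1ccccc1Cl)c1ccc(-c2ccccc2)cc1`: in a functional assay for agonist activity at G protein-coupled receptor 88 (Homo sapiens), read by HTRF and cAMP accumulation (on this read-out lower numbers stand for an effect already at smaller amounts and higher numbers for an effect only at larger amounts of compound), compound 1 gives only a limit, > 25000 nM.
Compound 2 `CC[C@H](C)[C@H](N)CN(C(=O)[C@@H]1C[C@H]1C1CCCCC1)c1ccc(-c2ccccc2)cc1`: in this assay compound 2 gives only a limit, > 25000 nM.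
Compound 3 `CC[C@H](C)[C@H](N)CN(C(=O)[C@@H]1C[C@H]1c1cc(F)cc(F)c1)c1ccc(-c2ccccc2)cc1`: in this assay compound 3 gives 960 nM.

Within the data shown here, compound 3 is thus the only compound with a number; the other two sit at the limit (the limit of > 25000 nM in this assay, at which 2 of the 3 values shown sit). Compound 4 `CC[C@H](C)[C@H](N)CN(C(=O)[C@@H]1C[C@H]1c1ccc(F)cc1F)c1ccc(-c2ccccc2)cc1` differs from compound 3 by 2,4-difluorophenyl in place of 3,5-difluorophenyl on a saturated ring carbon. The steps of an at least 26-fold lower number from compound 1 to compound 3 (1.41 log units; beyond the scatter) and an at least 26-fold lower number from compound 2 to compound 3 (1.41 log units; beyond the scatter) were both large, while a step that the two limits leave unreadable from compound 1 to compound 2 stays unreadable. Since the 2,4-difluorophenyl of compound 4 resembles the 2-chlorophenyl of compound 1 more closely than the 3,5-difluorophenyl of compound 3, a higher number is expected for compound 4, as a 6.3-fold higher number from compound 3 to compound 4 (0.80 log units; beyond the scatter). The estimate for compound 4 is 6000 nM, within 1500 nM to 25000 nM.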

Compound 4, half-maximal effective concentration: 1300 nM
The estimate for compound 4 lay 4.6-fold (0.66 log units) above the measured number; the whole stated range lies above it.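

In this assay, exchanging 3,5-difluorophenyl for 2,4-difluorophenyl gives a 1.4-fold higher number from compound 3 to compound 4 (0.13 log units; within the scatter), so the arrangement of the two fluorines on this ring, carried on the cyclopropane carbon, does not separate these compounds. The resemblance to the 2-chlorophenyl of compound 1 did not carry over, with an at least 19-fold lower number from compound 1 to compound 4 (1.28 log units; beyond the scatter) and an at least 19-fold lower number from compound 2 to compound 4 (1.28 log units; beyond the scatter). Both of these steps start from a limit and not from a number: the limit of > 25000 nM in this assay, at which 2 of the 4 values shown sit.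

On these data alone, whether a single fluorine, a 3,5-dichlorophenyl or a 4-methoxyphenyl would stay in this range remains open. So does what separates the 2-chlorophenyl from the 2,4-difluorophenyl.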